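Three inactive amides and a fourth awaiting test

This account rests on a few compounds, and the source may have more. Where it says the series, first, only, none or still open, it means among the compounds named here.

Measured so far:
compound 1, `COc1cccc(N2CCN(C(=O)C(C)N3C(=O)CCC3=O)CC2)c1`: 0%
compound 2, `CCC(C(=O)N1CCN(c2cccc(OC)c2)CC1)N1C(=O)CCC1=O`: 0%
compound 3, `CCC(C(=O)N1CCN(c2ccc(F)cc2)CC1)N1C(=O)CCC1=O`: 0%

All three were tested in a functional assay on the whole organism (strain Swiss) with Mus musculus as the target, in the maximal electroshock model, with a stated time of 2 h, at a dose of 300 mg/kg by the intraperitoneal route; on this read-out lower numbers stand for a weaker effect and higher numbers for a stronger effect at the one dose given. In this assay compound 1 gives 0%, compound 2 gives 0% and compound 3 gives 0%, so none of the three shows any effect at the dose used.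

Two single-point changes connect them. The change hydrogen in place of methyl on a saturated chain carbon, two bonds along the chain from an amide-type nitrogen in a ring and a carbonyl carbon gives no change at the digits printed from compound 2 to compound 1 (within the scatter). The change 4-fluorophenyl in place of 3-methoxyphenyl on an amine nitrogen in a ring gives no change at the digits printed from compound 2 to compound 3 (within the scatter). Among the compounds with values here, compound 3 thus stands level with compound 1 and compound 2; no pair among the three is separated by more than the scatter, and no order can be read into them.

Compound 4, `CC(C(=O)N1CCN(c2ccc(F)cc2)CC1)N1C(=O)CCC1=O`, is not yet measured. Within the data shown here, it differs from compound 3 by hydrogen in place of methyl on a saturated chain carbon, two bonds along the chain from an amide-type nitrogen in a ring and a carbonyl carbon, the same change as the one from compound 2 to compound 1, made here on the core of compound 3 instead of the core of compound 2; the place of the change is described in the same words in both cases. The two cores differ by 4-fluorophenyl in place of 3-methoxyphenyl on an amine nitrogen in a ring.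

Since the same change gave no change at the digits printed from compound 2 to compound 1 (within the scatter), and since compound 3 gives 0%, the expected step is no change at the digits printed from compound 3 to compound 4 (within the scatter). Compound 4 is therefore estimated at 0% in this assay, expected to fall between 0% and 10%; a result within the scatter of the three measured compounds is the expectation, and nothing in the data points to a departure from it.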

Compound 4, a percentage reported as activity, at one dose (the size of the read-out at that dose, not a potency): 50%
Estimate against measurement, compound 4: 50 percentage points below; measured number outside the range, above it.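

In this assay, hydrogen in place of methyl gives a number 50 percentage points higher from compound 3 to compound 4 (beyond the scatter), and 4-fluorophenyl in place of 3-methoxyphenyl gives a number 50 percentage points higher from compound 1 to compound 4 (beyond the scatter). The change from methyl to hydrogen on the saturated chain carbon therefore does not carry from one core to another with a fixed size: the same change on two cores in this assay, no change at the digits printed (within the scatter) from compound 2 to compound 1 and a number 50 percentage points higher (beyond the scatter) from compound 3 to compound 4, 50 percentage points apart, beyond the scatter of two such steps. The aryl change does not carry with a fixed size either, and in these four compounds the effect appears only where hydrogen and 4-fluorophenyl occur together, though a single set of four compounds tested at one dose does not show a general rule for the series or a reason for the result: the same change on two cores in this assay, no change at the digits printed (within the scatter) from compound 2 to compound 3 and a number 50 percentage points higher (beyond the scatter) from compound 1 to compound 4, 50 percentage points apart, beyond the scatter of two such steps.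

As far as these compounds go, it remains open whether other groups on the amine nitrogen in the ring, such as unsubstituted phenyl, 4-chlorophenyl or 3-fluorophenyl, also give a response when hydrogen stands on the chain carbon. From the compounds shown here alone, it also remains open how a longer chain, such as propyl, or a second methyl on that carbon would read with 4-fluorophenyl in place.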